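Replacing dimethylamino with ethylamino on a shared core

A few compounds are considered here, and "the series" means these few. Any claim that something is new, unique, unknown or untested is made for them only; others in the source may bear on it.

In a functional assay on HL-60 cells (Homo sapiens) for cytotoxicity, read by CellTiter-Blue, with a stated time of 48 h (on this read-out higher numbers stand for weaker inhibition and lower numbers for stronger inhibition), compound 1 (`C#CCOC(=O)CC1C(C(=O)OCC#C)=C(N)Oc2ccc(-c3ccc(N)cc3)cc21`) gives 610 nM and compound 2 (`C#CCOC(=O)CC1C(C(=O)OCC#C)=C(N)Oc2ccc(-c3ccc(N(C)C)cc3)cc21`) gives 2560 nM as the higher of the two numbers, so compound 2 stands at the weaker end of what has been measured. Compound 3 (`C#CCOC(=O)CC1C(C(=O)OCC#C)=C(N)Oc2ccc(-c3ccc(NCC)cc3)cc21`) differs from compound 2 in one group (ethylamino in place of dimethylamino on an aromatic carbon), with ethylamino in place of dimethylamino on an aromatic carbon, para to a large group. The two groups have the same atoms, joined differently, but ethylamino has a hydrogen-bond donor that dimethylamino lacks. Within the data shown here, the only measured step that bears on this is a 4.2-fold higher number from compound 1 to compound 2 (0.62 log units; beyond the scatter) for dimethylamino in place of amino, modest in size and beyond the scatter. Among the measured compounds shown here, no ethylamino compound has been measured, so this is a weak guide. Resting on that step, with compound 1 at 610 nM as the lower reference, a small move toward a lower number is expected in this assay for the new group. The expected step is a 1.8-fold lower number from compound 2 to compound 3 (0.26 log units; within the scatter) and may stay within the scatter. For compound 3 the estimated value is 1400 nM within an expected range from 600 nM to 3200 nM on this read-out.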

Compound 3, half-maximal inhibitory concentration: 7270 nM
Estimate against measurement, compound 3: 5.2-fold (0.72 log units) below; the measured number lies above the stated range.
By their numbers in this assay, from the lowest: compound 1; then compound 2; then compound 3.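

In this assay, the group on an aromatic carbon para to a large group proves sensitive to how its atoms are joined, not only to which atoms it holds: dimethylamino and ethylamino have the same atoms, yet the change gives a 2.8-fold higher number from compound 2 to compound 3 (0.45 log units; beyond the scatter). Ethylamino carries a hydrogen-bond donor that dimethylamino lacks, but the number moves further from that of compound 1 rather than back toward it, so compound 3 goes against any reading in which having that donor on the nitrogen is enough for a lower number. Placing ethyl on the nitrogen of the free amino group gives a 12-fold higher number from compound 1 to compound 3 (1.08 log units; beyond the scatter), a larger move than a 4.2-fold higher number from compound 1 to compound 2 (0.62 log units; beyond the scatter), so the free amino group remains the best of the three on this read-out.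

The compounds shown leave open whether the number climbs steadily with the size of the chain on the nitrogen, a question that methylamino and propylamino at the same place would help to answer. Nothing available here gives a reason for any of these moves.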